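The compounds below may be only part of what the source reports. "The series", "measured", "known", "first", "only" and "open" are said of these compounds alone.

Compound 1 `Cc1nc(C(NC(=O)C(=O)Nc2ccc(Cl)cc2)C2CCCCN2)sc1CO`: in an ADME assay on TZM-b1 cells (Homo sapiens) for cytotoxicity, read by XTT assay, with a stated time of 3 days (a lower number here means that less compound is tolerated, a higher number that more compound is tolerated), compound 1 gives > 22000 nM, which is a limit of the assay and not a number.
Compound 2 `Cc1nc(C(NC(=O)C(=O)Nc2ccc(Cl)c(F)c2)C2CCCCN2)sc1CO`: in this assay compound 2 gives 58400 nM.
Compound 3 `Cc1nc(C(NC(=O)C(=O)Nc2ccc(Cl)c(F)c2)C2CCCCN2)sc1CCO`: in this assay compound 3 gives 61000 nM.

Compound 3 stands level with compound 2, since the step of a 1.0-fold higher number from compound 2 to compound 3 (0.02 log units; within the scatter) lies within the scatter of repeated measurements. The step that the limit leaves unreadable from compound 1 to compound 2 cannot be sized because compound 1 sits at the limit of > 22000 nM in this assay, at which 1 of the 3 values shown sits.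

Compound 4 `Cc1nc(C(NC(=O)C(=O)NC2CCCCCC2)C2CCCCN2)sc1CCO` differs from compound 3 by cycloheptyl in place of 4-chloro-3-fluorophenyl on an amide-type nitrogen. Neither measured step touches this amide-type nitrogen: one changes an aromatic hydrogen, the other a saturated chain, and the only readable one was within the scatter. Among the compounds with values here, there is thus no step here that points to a change in tolerated concentration in either direction for this exchange, and a result near compound 3 is the plain expectation, with a wide range and a real chance that only a limit is reported.

Compound 4 is therefore expected to give 50000 nM in this assay, with a range from 20000 nM to 120000 nM. This estimate means a step of a 1.2-fold lower number from compound 3 to compound 4 (0.09 log units; within the scatter), expected to stay within the scatter.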

Compound 4, half-maximal cytotoxic concentration: > 88000 nM
Compound 4 gave a limit, no number; the forecaster's own chance of this, stated with the estimate: 35%; middle value at least 1.7-fold (0.24 log units) away from the limit.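

Compound 4 gives > 88000 nM in this assay, which is a limit of the assay and not a number. This is the only step shown that changes the group on the amide-type nitrogen, and an at least 1.4-fold higher number from compound 3 to compound 4 (0.15 log units; that floor lies within the scatter) shows that exchanging 4-chloro-3-fluorophenyl for cycloheptyl brings no drop in the tolerated concentration, so the aromatic ring with its chlorine and fluorine is not required here for a high number. How far compound 4 truly lies from compound 3 cannot be read because compound 4 sits at a limit: the limit of > 88000 nM in this assay, at which 1 of the 4 values shown sits.

A single carbon ring cannot show how general this is. The compounds shown leave open whether a cycloheptyl ring carrying an amine or a carboxylic acid, or a plain open hexyl chain on this nitrogen, would be tolerated equally well.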